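Working notes: oxazolyl for pyridyl on the shared core

The source may hold more compounds than are shown below. What is called first, only, known or untested is meant among the compounds shown, and "the series" means these compounds.

Measured so far:
compound 1, `O=C(c1cccnc1)N1CCC(C(=O)N2N=CCC2c2ccccc2)CC1`, a physicochemical assay for lipophilicity, read by HPLC, measured as chromatographic lipophilicity, at pH 7.4; a higher number here means a more lipophilic compound, a lower number a more polar compound: 2.6
compound 2, `O=C(C1CCN(c2ccccc2)CC1)N1N=CCC1c1ccccc1`, this assay: 6.3
compound 3, `O=C(c1ccccn1)N1CCC(C(=O)N2N=CCC2c2ccccc2)CC1`, this assay: 3.1

Compound 3 stands second highest of the three. Its nearest neighbour is compound 1, with a number 0.50 log units higher from compound 1 to compound 3 (beyond the scatter). Its furthest is compound 2, with a number 3.20 log units lower from compound 2 to compound 3 (beyond the scatter); the companion step a number 3.70 log units higher from compound 1 to compound 2 (beyond the scatter) shows how far the phenyl-bearing compound 2 sits from both acyl-bearing compounds.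

Compound 4, `O=C(c1cocn1)N1CCC(C(=O)N2N=CCC2c2ccccc2)CC1`, differs from compound 3 in one place: 1,3-oxazol-4-yl in place of pyridin-2-yl on a carbonyl carbon. Within the data shown here, the only measured step that bears on this kind of change is the ring swap on the carbonyl carbon from compound 1 to compound 3, which was modest. The two large steps involving compound 2 exchange the whole carbonyl-bearing group for phenyl on the ring nitrogen and are a different kind of change; they are not taken as a guide here. Given the modest size of a number 0.50 log units higher from compound 1 to compound 3 (beyond the scatter), a modest step is expected, and the direction is expected to be downward: a number 0.70 log units lower from compound 3 to compound 4 (beyond the scatter).

Compound 4 is therefore estimated at 2.4, with an expected range of 1.7 to 3.1.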

Compound 4, distribution coefficient: 2.9
Beside the measured number, compound 4's estimate is 0.50 log units below it; the range from low to high includes it.
By their numbers in this assay, from the lowest: compounds 1, 4 and 3 (each within the scatter of the next, the first and the last beyond it); then compound 2.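

In this assay, 1,3-oxazol-4-yl on a carbonyl carbon can take the place of either pyridyl ring without a step beyond the scatter, the readings being a number 0.20 log units lower from compound 3 to compound 4 (within the scatter) and a number 0.30 log units higher from compound 1 to compound 4 (within the scatter). Compound 4 therefore cannot be ordered against either pyridyl compound, even though those two stand apart by a number 0.50 log units higher from compound 1 to compound 3 (beyond the scatter), while a number 3.40 log units lower from compound 2 to compound 4 (beyond the scatter) is of the same large size as a number 3.20 log units lower from compound 2 to compound 3 (beyond the scatter), so exchanging the whole carbonyl-bearing group for phenyl remains by far the bigger kind of change among these compounds. No supporting data accompany these steps to account for their sizes.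

On these data alone, all three groups compared on this carbonyl carbon are aromatic rings, so it stays open whether the small steps would hold for a group of another kind there, such as an amine, a carboxylic acid or a longer chain. As far as these compounds go, it also stays open whether 1,3-oxazol-4-yl and pyridin-2-yl would read as closely on a core other than the shared core, where alone they appear here.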